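The source may hold more compounds than are shown below. What is called first, only, known or untested is meant among the compounds shown, and "the series" means these compounds.

Measured so far:
compound 1 `CC(=O)N1N=C(c2ccc(C)cc2)CC1c1ccc(C(=O)OC(C)Cn2c([N+](=O)[O-])cnc2C)cc1` — 72100 nM
compound 2 `COc1ccc(C2=NN(C(C)=O)C(c3ccc(C(=O)OC(C)Cn4c([N+](=O)[O-])cnc4C)cc3)C2)cc1` — 35100 nM

Both compounds were tested in a functional assay on HeLa cells (Homo sapiens) for antiproliferative activity, read by MTT assay, with a stated time of 12 h; on this read-out lower numbers stand for stronger inhibition and higher numbers for weaker inhibition. Among the measured compounds shown here, compound 2 holds the lower of the two numbers; the only step available, a 2.1-fold lower number from compound 1 to compound 2 (0.31 log units; beyond the scatter), arises from the change methoxy in place of methyl on an aromatic carbon. On the two values shown, compound 2 therefore stands at the lower end.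

Compound 3 `CC(=O)N1N=C(c2ccc([N+](=O)[O-])cc2)CC1c1ccc(C(=O)OC(C)Cn2c([N+](=O)[O-])cnc2C)cc1` has not yet been measured in this assay. It differs from compound 2 by nitro in place of methoxy on an aromatic carbon; cut one bond further out, 4-methoxyphenyl becomes 4-nitrophenyl. For the measured compounds named here, the single measured step bears on the same position, but exchanged methyl for methoxy, not methoxy for nitro, so it gives no direct precedent for the present change. That step was modest, and nothing here suggests a larger effect for the new substitution. A step of about the same size or none beyond the scatter is expected, with no firm direction.

For compound 3 the estimate is 32000 nM, range 10000 nM to 90000 nM, which would mean a 1.1-fold lower number from compound 2 to compound 3 (0.04 log units; within the scatter).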

Compound 3, half-maximal inhibitory concentration: 3780 nM
Compound 3: middle estimate off by 8.5-fold (0.93 log units), on the high side; measured number outside the range, below it.
By their numbers in this assay, from the lowest: compound 3; then compound 2; then compound 1.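

In this assay, the group on the aromatic carbon para to a large group matters more than the first pair suggested: 4-nitrophenyl in place of 4-methoxyphenyl gives a 9.3-fold lower number from compound 2 to compound 3 (0.97 log units; beyond the scatter), a clearly larger step than the only one previously seen at this position. Set against methyl, nitro gives a 19-fold lower number from compound 1 to compound 3 (1.28 log units; beyond the scatter), so the three groups rank nitro, methoxy, methyl from lowest number to highest, with every step between them beyond the scatter. No measurement is at hand that would explain this order.

Three groups at one position cannot show whether the large step is particular to nitro or would also appear with other groups there, such as a nitrile, a trifluoromethyl, an amine or a carboxylic acid. On these data alone, all three numbers also come from the single read-out of this assay, so whether the same order holds in other cells or at other exposure times remains open.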